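Two Phenyltriazole Sulfonamides and a Methyl Shift

The source may hold more compounds than are shown below. What is called first, only, known or untested is meant among the compounds shown, and "the series" means these compounds.

Three sulfonamides built on a shared core have been measured in a functional assay on HepG2 cells (Homo sapiens) for antiproliferative activity, read by MTT assay, with a stated time of 24 h; on this read-out higher numbers stand for weaker inhibition and lower numbers for stronger inhibition. Compound 1 `O=c1[nH]cc(S(=O)(=O)Nc2cccc(-c3cn(-c4ccccc4)nn3)c2)c(=O)[nH]1` gives 11200 nM in this assay. Compound 2 `Cc1cccc(-n2cc(-c3cccc(NS(=O)(=O)c4c[nH]c(=O)[nH]c4=O)c3)nn2)c1` carries the change methyl in place of hydrogen on an aromatic carbon and gives 7050 nM; the step of a 1.6-fold lower number from compound 1 to compound 2 (0.20 log units; within the scatter) is within the scatter. Compound 3 `O=c1[nH]cc(S(=O)(=O)Nc2ccc(-c3cn(-c4ccccc4)nn3)cc2)c(=O)[nH]1` has the same atoms as compound 1 joined differently, and the difference between the two cores is not broken down here; in this assay compound 3 gives 18000 nM, which against compound 2 is a gap beyond the scatter, while against compound 1 the two numbers fall within the scatter of each other.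

Compound 4 `Cc1ccccc1-n1cc(-c2ccc(NS(=O)(=O)c3c[nH]c(=O)[nH]c3=O)cc2)nn1` has not yet been measured. It stands to compound 3 as compound 2 stands to compound 1, with the change (methyl in place of hydrogen on an aromatic carbon). The two changes are the same kind of change but not the same: in compound 2 the methyl enters meta to a large group, whereas in compound 4 it enters ortho to a large group. For the measured compounds named here, the only measured guide is the step from compound 1 to compound 2, which lay within the scatter.

On that basis compound 4 is expected to give about 13000 nM in this assay, with a likely range of 6000 nM to 30000 nM. The expected step of a 1.4-fold lower number from compound 3 to compound 4 (0.14 log units; within the scatter) is estimated to be modest because the earlier step of a 1.6-fold lower number from compound 1 to compound 2 (0.20 log units; within the scatter) was itself small, and the difference in where the methyl enters leaves the direction uncertain.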

Compound 4, half-maximal inhibitory concentration: 14500 nM
For compound 4 the middle estimate is 1.1-fold (0.05 log units) below the measured one; low and high end bracket the measured number.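

In this assay methyl in place of hydrogen leaves compound 4 within the scatter of compound 3, the step being a 1.2-fold lower number from compound 3 to compound 4 (0.09 log units; within the scatter). Set beside the step on the core of compound 1, the change reads alike on both cores, with neither step beyond the scatter and no difference between them that can be told from repeated measurement: the same change on two cores in this assay, a 1.6-fold lower number (0.20 log units; within the scatter) from compound 1 to compound 2 and a 1.2-fold lower number (0.09 log units; within the scatter) from compound 3 to compound 4, 1.3-fold (0.11 log units) apart, within the scatter of two such steps This agreement shows only that the change produced no step beyond the scatter on either core; it does not show that a real effect of the methyl carries from one core to the other, and since the methyl of compound 4, ortho to a large group, does not sit where the methyl of compound 2 sits, any effect of its place cannot be separated from that of the core.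

The compounds shown leave open whether methyl at one and the same place on the phenyl would give matching steps on the two cores. They also leave open whether a different group there, such as a chlorine, a methoxy group, an amine or a carboxylic acid, would give a step beyond the scatter on either core.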